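This account rests on a few compounds, and the source may have more. Where it says the series, first, only, none or still open, it means among the compounds named here.

Three measured compounds share one core and differ only in the group carried on an aromatic nitrogen. Compound 1 `O=C(O)c1cc(-c2ccc(-c3ccc(Cl)cc3Cl)cc2)n(-c2cccnc2)n1` gives 47000 nM in an assay on isolated protein for inhibition of methionine--tRNA ligase, cytoplasmic (Homo sapiens); a lower number here means a stronger inhibitor, a higher number a weaker inhibitor. Compound 3 `O=C(O)c1cc(-c2ccc(-c3ccc(Cl)cc3Cl)cc2)n(Cc2ccncc2)n1` gives 26200 nM in this assay; the step of a 1.8-fold lower number from compound 1 to compound 3 (0.25 log units; within the scatter) lies within the scatter, so compound 3 and compound 1 cannot be told apart, though compound 3 has the lower of the two numbers reported. Compound 2 `COc1ccc(-n2nc(C(=O)O)cc2-c2ccc(-c3ccc(Cl)cc3Cl)cc2)cc1` reaches only a limit in this assay, > 100000 nM, which is the limit of > 100000 nM in this assay, at which 1 of the 3 values shown sits. The steps of an at least 2.1-fold higher number from compound 1 to compound 2 (0.32 log units; beyond the scatter) and an at least 3.8-fold lower number from compound 2 to compound 3 (0.58 log units; beyond the scatter) are both at least modest.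

Compound 4 `O=C(O)Cn1nc(C(=O)O)cc1-c1ccc(-c2ccc(Cl)cc2Cl)cc1` is not yet measured. It differs from compound 3 by carboxy in place of pyridin-4-yl on a saturated chain carbon bound to an aromatic nitrogen. All three measured steps change the same position, yet each exchanges one ring-bearing group for another, and none removes the ring, so they set only a loose frame: changes here have ranged from within the scatter to at least modest. A weakening of about a 1.9-fold higher number from compound 3 to compound 4 (0.28 log units; within the scatter) is therefore expected, and compound 4 is estimated at 50000 nM, within 12000 nM to 200000 nM.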

Compound 4, half-maximal inhibitory concentration: 100000 nM
The estimate for compound 4 lay 2.0-fold (0.30 log units) below the measured number; low and high end bracket the measured number.
By their numbers in this assay, from the lowest: compounds 3 and 1 (each within the scatter of the next); then compound 4.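

For the compounds shown here, compound 4 is the only compound here with no ring on this group. In this assay, carboxy in place of pyridin-4-yl on a saturated chain carbon bound to an aromatic nitrogen gives a 3.8-fold higher number from compound 3 to compound 4 (0.58 log units; beyond the scatter), while carboxymethyl in place of pyridin-3-yl on an aromatic nitrogen gives a 2.1-fold higher number from compound 1 to compound 4 (0.33 log units; beyond the scatter). A pyridine ring in this group, whether held on a chain carbon or set directly on the aromatic nitrogen, thus goes with lower numbers than carboxymethyl, though both steps are only modest, and compound 2, which carries a ring of its own, goes against any rule that a ring alone is enough. Compound 2 stands only at a limit: the limit of > 100000 nM in this assay, at which 1 of the 4 values shown sits. Carboxymethyl in place of 4-methoxyphenyl on an aromatic nitrogen gives a number no higher from compound 2 to compound 4 (the limit leaves the size open), a step whose size cannot be read.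

The compounds shown cannot separate the loss of the ring from the arrival of the carboxy group. A plain methyl group, an amine on the chain, or a longer chain ending in a carboxylic acid would begin to tell these two apart.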